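Swapping Methylsulfanyl for Methyl on a Shared Core

The compounds below may be only part of what the source reports. "The series", "measured", "known", "first", "only" and "open" are said of these compounds alone.

Measured compounds:
compound 1, `CNc1ccnc(Nc2ccc(Cl)c(OCC=C(C)C)c2)n1`: 690 nM
compound 2, `CSc1ccnc(Nc2ccc(Cl)c(OCC=C(C)C)c2)n1`: 2800 nM

In an ADME assay on MT2 cells (Homo sapiens) for cytotoxicity (on this read-out lower numbers stand for higher toxicity in this test and higher numbers for lower toxicity in this test), compound 1 gives 690 nM, and compound 2 gives 2800 nM. For the measured compounds named here, the single measured step is a 4.1-fold higher number from compound 1 to compound 2 (0.61 log units; beyond the scatter). Compound 2 therefore stands at the highest of the two numbers, with compound 1 nearest and clearly lower.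

Compound 3, `CC(C)=CCOc1cc(Nc2nccc(C)n2)ccc1Cl`, differs from compound 2 in one place: methyl in place of methylsulfanyl on an aromatic carbon. Going by the values given here, the one measured step also exchanged the group on an aromatic carbon of the shared core and moved the number by a modest amount, so a change of similar or smaller size is plausible here, but nothing measured points to a direction. Compound 3 is therefore expected to land near compound 2, with the step of a 1.4-fold lower number from compound 2 to compound 3 (0.15 log units; within the scatter) as the estimate. For compound 3 the expected value is 2000 nM, in a range from 700 nM to 5500 nM.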

Compound 3, half-maximal cytotoxic concentration: 150 nM
For compound 3 the middle estimate is 13-fold (1.12 log units) above the measured one, outside the stated range (below it).
By their numbers in this assay, from the lowest: compound 3; then compound 1; then compound 2.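

In this assay, this position proves far more sensitive than the first pair suggested: methyl in place of methylsulfanyl gives a 19-fold lower number from compound 2 to compound 3 (1.27 log units; beyond the scatter), and methyl in place of methylamino gives a 4.6-fold lower number from compound 1 to compound 3 (0.66 log units; beyond the scatter), both beyond the scatter. Compound 3, with methyl, therefore has the lowest number of the three, which means the highest toxicity in this test, while the two groups carrying a sulfur or nitrogen atom both give higher numbers. No supporting evidence is available to account for the size of these steps.

Still open, on these data alone, is whether methoxy, ethyl or a plain hydrogen at this position would give a number closer to that of methyl or of methylsulfanyl. Also open, as far as these compounds go, is whether the same order of groups would hold if the 3-methylbut-2-enyloxy chain of the shared core were replaced by a shorter chain.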